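Sulfoxide series: methyl for methoxy, cytotoxicity limits

This account rests on a few compounds, and the source may have more. Where it says the series, first, only, none or still open, it means among the compounds named here.

Measured so far:
compound 1, `COc1ccccc1[S+]([O-])c1cccc(N)c1C#N`, > 200000 nM
compound 2, `COc1cccc([S+]([O-])c2cccc(N)c2C#N)c1`, > 80000 nM
compound 3, `Cc1ccccc1[S+]([O-])c1cccc(N)c1C#N`, > 200000 nM

All three values come from a functional assay on MT4 cells (Homo sapiens) for cytotoxicity; on this read-out higher numbers stand for weaker inhibition and lower numbers for stronger inhibition. For compound 1 the value > 200000 nM is a limit of the assay, not a number. For compound 2 the value > 80000 nM is likewise a limit. For compound 3 the value > 200000 nM is a limit as well.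

Compound 1 and compound 3 differ by methyl in place of methoxy on an aromatic carbon. The step between them is a step that the two limits leave unreadable from compound 1 to compound 3; it cannot be read because the limit of > 200000 nM in this assay, at which 2 of the 3 values shown sit, is where both values sit.

Compound 2 is built from the same atoms as compound 1, joined differently; the difference between the two cores is not broken down here. Compound 4, `Cc1cccc([S+]([O-])c2cccc(N)c2C#N)c1`, is not yet measured in this assay. It stands to compound 2 as compound 3 stands to compound 1, by methyl in place of methoxy on an aromatic carbon. The two changes are the same kind of change, not the same: from compound 1 to compound 3 the place is ortho to a large group, from compound 2 to compound 4 it is meta to a large group.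

Compound 4 is expected to sit near compound 2, the expected step being a step that the limit leaves unreadable from compound 2 to compound 4, resting on compound 2 at the limit of > 80000 nM in this assay, at which 1 of the 3 values shown sits, and on the unreadable step from compound 1 to compound 3. The estimate for compound 4 in this assay is 150000 nM, between 80000 nM and 300000 nM, most likely again reported only as a limit.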

Compound 4, half-maximal inhibitory concentration: > 200000 nM
Compound 4 ended at the assay's limit (the forecaster's own chance of this, stated with the estimate: 85%); middle value at least 1.3-fold (0.12 log units) away from the limit.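

In this assay compound 4 gives > 200000 nM, a limit of the assay and not a number, and with compound 2 also at a limit, no step can be read between compound 2 and compound 4. With all four values at limits, the compounds shown leave open whether methyl in place of methoxy on an aromatic carbon changes the read-out at all, and at what concentration any of them would reach half-maximal inhibition.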